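The compounds below may be only part of what the source reports. "The series", "measured", "known", "first", "only" and "open" are said of these compounds alone.

Compound 1, `CCOc1c(-c2cc(OC)c(OC)c(OC)c2)oc2ccccc2c1=O`, gives 900 nM in a functional assay on PC-3 cells (Homo sapiens) for antiproliferative activity, read by WST assay, with a stated time of 3 days; a higher number here means a weaker inhibitor, a lower number a stronger inhibitor.
Compound 2, `CCCC(C)Oc1c(-c2cc(OC)c(OC)c(OC)c2)oc2ccccc2c1=O`, gives 49300 nM in this assay.

Within the data shown here, compound 1 holds the lowest of the two numbers measured; compound 2 is its only neighbour, and that neighbour is far weaker. Compound 3, `CCCN(CCC)CCCOc1c(-c2cc(OC)c(OC)c(OC)c2)oc2ccccc2c1=O`, has not been measured. It differs from compound 1 by (dipropylamino)methyl in place of hydrogen on a saturated chain carbon, two bonds along the chain from an oxygen on an aromatic ring.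

Among the measured compounds shown here, the one measured step that bears on this change is a 55-fold higher number from compound 1 to compound 2 (1.74 log units; beyond the scatter), a large loss for a fairly small enlargement of the same chain. The change in compound 3 is larger still in what it adds, though it sits one carbon further from the oxygen and leaves the carbon bound to that oxygen untouched. A weakening is therefore expected, but its size is uncertain, and compound 3 is estimated to sit at 5000 nM, within a range from 1000 nM to 30000 nM, a step of a 5.6-fold higher number from compound 1 to compound 3 (0.74 log units; beyond the scatter).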

Compound 3, half-maximal inhibitory concentration: 16800 nM
Estimate against measurement, compound 3: 3.4-fold (0.53 log units) below; the measured number falls inside the stated range.
By their numbers in this assay, from the lowest: compound 1; then compound 3; then compound 2.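

In this assay, compound 1 does not keep its place when the ethoxy chain is extended: (dipropylamino)methyl on the saturated chain carbon, two bonds along the chain from the oxygen, brings a large loss (a 19-fold higher number from compound 1 to compound 3 (1.27 log units; beyond the scatter)). The loss differs between groups on this oxygen, since 3-(dipropylamino)propyl in place of 1-methylbutyl brings a modest gain (a 2.9-fold lower number from compound 2 to compound 3 (0.47 log units; beyond the scatter)), so this position does not respond to every enlargement alike. Nothing shown explains why either group costs what it does.

The compounds shown do not separate the effect of the amine nitrogen from that of the added chain, which a plain hexyl chain on the same oxygen would help to do. On these data alone, whether a smaller amine, such as dimethylamino at the end of the propyl chain, would lose less also stays open.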